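Compound 4 estimated without a starting number

This account rests on a few compounds, and the source may have more. Where it says the series, first, only, none or still open, it means among the compounds named here.

Measured in a physicochemical assay for lipophilicity, using the shake flask method, at pH 7.4 (on this read-out lower numbers stand for lower lipophilicity and higher numbers for higher lipophilicity), are these compounds
compound 1 `CC(Oc1ccccc1)C(=O)Nc1ccc(OCC(=O)O)c(F)c1` with -0.18
compound 2 `CC(Oc1ccccc1F)C(=O)Nc1ccc(OCC(=O)O)c(F)c1` with 0.07
compound 3 `CCOc1ccc(OC(C)C(=O)Nc2ccc(OCC(=O)O)c(F)c2)cc1` with "not determined" (no result reported)

Compound 3 therefore offers no number to start from. Compound 4 `Cc1ccc(OC(C)C(=O)Nc2ccc(OCC(=O)O)c(F)c2)cc1C` differs from it by 3,4-dimethylphenyl in place of 4-ethoxyphenyl on an oxygen on a saturated carbon and so carries 3,4-dimethylphenyl in place of 4-ethoxyphenyl on an oxygen on a saturated carbon. Among the compounds with values here, the only measured step is a number 0.25 log units higher from compound 1 to compound 2 (within the scatter) for fluoro in place of hydrogen on an aromatic carbon. That is a different change, so it gives neither size nor direction here. No step size can be expected in this assay without a number for compound 3. The expectation rests instead on compound 1 at -0.18 and compound 2 at 0.07 and is set somewhat higher, without a measured step behind it. For compound 4 the estimated value is 0.5 with an expected range from 0 to 1 on this scale.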

Compound 4, distribution coefficient: 0.33
The estimate for compound 4 lay 0.17 log units above the measured number; measured number inside the range.
By their numbers in this assay, from the lowest: compounds 1, 2 and 4 (each within the scatter of the next, the first and the last beyond it).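

In this assay, within the data shown here, the change from phenyl to 3,4-dimethylphenyl on this oxygen-bearing saturated carbon gives a number 0.51 log units higher from compound 1 to compound 4 (beyond the scatter) and is the first step at this position to pass the scatter. Putting 3,4-dimethylphenyl in place of 2-fluorophenyl gives a number 0.26 log units higher from compound 2 to compound 4 (within the scatter) and does not separate these two groups. Nothing measured accounts for either step. The change from 4-ethoxyphenyl cannot be read, since compound 3 has no number. On these data alone, how a ring carrying an amine or a longer chain would read at this position stays open.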